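Swapping (pyridin-2-yl)methyl for phenyl

The source may hold more compounds than are shown below. What is called first, only, known or untested is meant among the compounds shown, and "the series" means these compounds.

Going by the values given here, only two compounds have numbers so far. In a functional assay on a cell-free system (plasma, Homo sapiens), with a stated time of 3 min (a lower number here means a stronger inhibitor, a higher number a weaker inhibitor), compound 1 `CC(C)(C)OC[C@@H](O)C(=O)N1[C@H](C(=O)NCc2cc(Cl)ccc2-n2cnnn2)C[C@@H]2C[C@@H]21` gives 500 nM. Compound 2 `O=C(NCc1cc(Cl)ccc1-n1cnnn1)[C@@H]1[C@@H]2C[C@@H]2CN1C(=O)[C@H](O)Cc1ccccn1` gives 1700 nM, the higher of the two numbers and so the weaker inhibitor of the pair, and the gap between them lies beyond the usual scatter.

Compound 3 `O=C(NCc1cc(Cl)ccc1-n1cnnn1)[C@@H]1[C@@H]2C[C@@H]2CN1C(=O)[C@H](O)c1ccccc1` keeps the rest of compound 2 but carries phenyl in place of (pyridin-2-yl)methyl on a saturated chain carbon bound to a carbonyl carbon and an oxygen on a saturated carbon. Among the compounds with values here, no measured pair shows this change or any other single change, so the data give no direct guide to its size or direction. A modest move toward a lower number in this assay is expected, though a result within the scatter of compound 2 would be no surprise. The expected step is a 2.1-fold lower number from compound 2 to compound 3 (0.33 log units; beyond the scatter). For compound 3 the estimated value is 800 nM, with an expected range of 220 nM to 2800 nM.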

Compound 3, half-maximal inhibitory concentration: 700 nM
Compound 3: the middle estimate sits 1.1-fold (0.06 log units) above what was measured; the range from low to high includes it.
By their numbers in this assay, from the lowest: compounds 1 and 3 (each within the scatter of the next); then compound 2.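

Going by these compounds alone, at this saturated chain carbon bound to a carbonyl carbon and an oxygen on a saturated carbon, the exchange gives the first comparison in this assay of two compounds that differ in one place: phenyl in place of (pyridin-2-yl)methyl brings a 2.4-fold lower number from compound 2 to compound 3 (0.39 log units; beyond the scatter), a modest step. The position therefore responds to the group it carries, and here the carbon-only aromatic ring goes with the lower number, although this single pair cannot show how general that is. The exchange also changes two things at once, removing both the ring nitrogen and the methyl link, and no measurement given here bears on why the number moved.

The compounds shown do not separate those two changes, since a benzyl group or a directly attached pyridin-2-yl ring at the same carbon would be needed to tell the ring nitrogen from the methyl link. Also open, on these data alone, is how this position responds to a substituted phenyl ring, such as a 4-fluorophenyl or 4-methoxyphenyl group, or to a group of a different kind, such as an amine or a carboxylic acid.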